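Swapping Chloro for Trifluoromethyl on the Aryl Ring

A few compounds are considered here, and "the series" means these few. Any claim that something is new, unique, unknown or untested is made for them only; others in the source may bear on it.

Measured compounds:
- compound 1, `CCOC(=O)c1cnc(-c2cccs2)nc1NN1C(=O)C=C(C)C1=O`, giving 20 nM in a functional assay on Jurkat cells for inhibition of nuclear factor NF-kappa-B complex (Homo sapiens); on this read-out lower numbers stand for stronger inhibition and higher numbers for weaker inhibition
- compound 2, `CCOC(=O)c1cnc(-c2ccc(Cl)cc2)nc1NN1C(=O)C=C(C)C1=O`, giving 300 nM in this assay

Compound 2 holds the highest of the two numbers in this assay; its nearest neighbour is compound 1, and the step of a 15-fold higher number from compound 1 to compound 2 (1.18 log units; beyond the scatter) came with 4-chlorophenyl in place of thiophen-2-yl on an aromatic carbon. Compound 3, `CCOC(=O)c1cnc(-c2ccc(C(F)(F)F)cc2)nc1NN1C(=O)C=C(C)C1=O`, is not yet measured. It differs from compound 2 by trifluoromethyl in place of chloro on an aromatic carbon, on an aromatic carbon of a six-membered aromatic ring of carbon only, para to a large group.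

Among the compounds with values here, no measured step covers this change: the single known step concerns the exchange of one aryl ring for another, not a substituent on the 4-chlorophenyl ring, so it gives no guidance on direction. The estimate therefore rests on compound 2 alone. Compound 3 is expected to stay close to its parent, with no change at the digits printed from compound 2 to compound 3 (within the scatter) as the estimated step, not beyond the scatter. The estimated value for compound 3 in this assay is 300 nM, with a range from 100 nM to 900 nM.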

Compound 3, half-maximal inhibitory concentration: 400 nM
The estimate for compound 3 lay 1.3-fold (0.12 log units) below the measured number; the range from low to high includes it.
By their numbers in this assay, from the lowest: compound 1; then compounds 2 and 3 (each within the scatter of the next).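

In this assay, the step of a 1.3-fold higher number from compound 2 to compound 3 (0.12 log units; within the scatter) shows that, on this aromatic carbon para to a large group, chloro and trifluoromethyl cannot be told apart, even though the entering group counts four heavy atoms against one. The step of a 20-fold higher number from compound 1 to compound 3 (1.30 log units; beyond the scatter) is large and runs the same way as the earlier step of a 15-fold higher number from compound 1 to compound 2 (1.18 log units; beyond the scatter), so among these three compounds both para-substituted phenyl rings sit well apart from the thiophen-2-yl ring of compound 1, and none of the three goes against this. Nothing available explains either the lack of a difference between compound 2 and compound 3 or the gap to compound 1.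

The compounds shown leave open whether the large gap to compound 1 goes with the phenyl ring itself or with its substituent, since a plain phenyl ring stands among none of them. They also leave open whether a group of another kind at this place, such as an amine or a carboxylic acid, would stay with compound 2 and compound 3 or move away from them.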